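This account rests on a few compounds, and the source may have more. Where it says the series, first, only, none or still open, it means among the compounds named here.

In an assay on isolated protein for inhibition of thyroid hormone receptor beta (Homo sapiens), read by fluorescence, with a stated time of 30 min (on this read-out lower numbers stand for stronger inhibition and higher numbers for weaker inhibition), compound 1 `COc1cc(C(=O)N2CCCC2(C)C)cc2nc(NCc3cccc(Cl)c3)oc12` gives 47 nM, and compound 2 `COc1cc(C(=O)N2CCC(O)C(C)C2)cc2nc(NCc3cccc(Cl)c3)oc12` gives 25 nM; the step of a 1.9-fold lower number from compound 1 to compound 2 (0.27 log units; within the scatter) leaves the two numbers within the scatter of each other, so compound 2 sits level with compound 1 on this read-out. Compound 3 `COc1cc(C(=O)N2CCC(O)C(C)C2)cc2nc(NCc3cc(Cl)ccn3)oc12` carries 4-chloropyridin-2-yl in place of 3-chlorophenyl on a saturated chain carbon bound to a nitrogen on an aromatic ring. Among the compounds with values here, no measured step touches this part of the shared core, so nothing in the data points to a direction. He expects for compound 3 a step of a 1.3-fold higher number from compound 2 to compound 3 (0.11 log units; within the scatter) in this assay, no larger than the scatter. His estimate for compound 3 is 32 nM, in the range 10 nM to 100 nM.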

Compound 3, half-maximal inhibitory concentration: 190 nM
The estimate for compound 3 lay 5.9-fold (0.77 log units) below the measured number; measured number outside the range, above it.
By their numbers in this assay, from the lowest: compounds 2 and 1 (each within the scatter of the next); then compound 3.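

In this assay, 4-chloropyridin-2-yl in place of 3-chlorophenyl on a saturated chain carbon bound to a nitrogen on an aromatic ring gives a 7.6-fold higher number from compound 2 to compound 3 (0.88 log units; beyond the scatter), the only step shown that lies beyond the scatter. This position therefore registers on the read-out, and the change brings one ring nitrogen and one hydrogen-bond acceptor while the chlorine's number in the name also differs. Nothing measured here offers a reason for this step.

The compounds shown leave open whether the ring nitrogen or the chlorine's placement drives the step. A 3-chloropyridin-2-yl or an unsubstituted phenyl at this place could begin to separate the two.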